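Capping the phenol: from compound 2 to compound 3

The compounds below may be only part of what the source reports. "The series", "measured", "known", "first", "only" and "open" are said of these compounds alone.

Compound 1 `Cn1c(Cc2nn(C)c(=O)c3ccccc23)nnc1SCCCCCCCC(=O)Nc1ccccc1O` and compound 2 `Cn1c(Cc2nn(C)c(=O)c3ccccc23)nnc1SCCCCCCCC(=O)Nc1ccc(O)cc1` share one core and differ only in the hydroxyphenyl on the amide nitrogen. In an assay on isolated protein (Mus musculus) for inhibition of IL15-IL15 receptor (Homo sapiens), read by resazurin assay, with stated times of 30 min and 2.5 days (a higher number here means a weaker inhibitor, a lower number a stronger inhibitor), compound 1 gives 27000 nM. Compound 2 reaches only the limit of this assay, > 30000 nM. The step of an at least 1.1-fold higher number from compound 1 to compound 2 (0.04 log units; that floor lies within the scatter) rests on that limit of > 30000 nM in this assay, at which 1 of the 2 values shown sits, and says little beyond placing compound 2 at the weak end of the pair. Compound 3 `CCCOc1ccc(NC(=O)CCCCCCCSc2nnc(Cc3nn(C)c(=O)c4ccccc34)n2C)cc1` carries propyl in place of hydrogen on an oxygen on an aromatic ring. No measured step touches this change: the single step shown exchanges 2-hydroxyphenyl for 4-hydroxyphenyl and leaves the hydroxy group itself intact. No shift beyond the scatter is therefore expected for compound 3 relative to compound 2 in this assay, and compound 3 is expected to stay near the weak end. The estimate for compound 3 is 35000 nM, in a range from 10000 nM to 120000 nM. The expected step that the limit leaves unreadable from compound 2 to compound 3 is essentially flat.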

Compound 3, half-maximal inhibitory concentration: 1600 nM
For compound 3 the middle estimate is 22-fold (1.34 log units) above the measured one; the measured number lies below the stated range.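

In this assay, the oxygen on the aromatic ring proves to be a place where a change counts: propyl in place of hydrogen gives an at least 18-fold lower number from compound 2 to compound 3 (1.27 log units; beyond the scatter), whereas the floor of the earlier step between the two hydroxyphenyl compounds lay within the scatter. The 4-propoxyphenyl group also stands clear of the 2-hydroxyphenyl group on the amide-type nitrogen, with a 17-fold lower number from compound 1 to compound 3 (1.23 log units; beyond the scatter), so the gain does not rest on the limit alone. The step from the 4-hydroxyphenyl compound is still only a floor, set by a limit for compound 2: the limit of > 30000 nM in this assay, at which 1 of the 3 values shown sits.

The compounds shown carry only one ether chain on this oxygen, so it remains open whether a methoxy or a butoxy group would do better or worse. They also leave open whether the oxygen itself matters, which a plain propyl chain or an amine on the ring could test.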